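A Second Heptylcarbonyl on a Compound at the Limit

The source may report more compounds than this note shows. Statements on the series, on what has been measured and on what is new or still open speak of the compounds shown alone.

Compound 1 `CCCCCCCC(=O)Oc1cc(C(=O)C2=C3OC(C)(C)[C@@H](CC=C(C)C)C[C@@]34C[C@@H](CC=C(C)C)C(C)(C)[C@H]3CCC(C)(C)O[C@]34OC2=O)ccc1O` carries a heptylcarbonyl on an oxygen on an aromatic ring, where compound 2 `CC(C)=CC[C@H]1C[C@]23C[C@@H](CC=C(C)C)C(C)(C)[C@H]4CCC(C)(C)O[C@]42OC(=O)C(C(=O)c2ccc(O)c(O)c2)=C3OC1(C)C` has hydrogen. In a functional assay on HeLa cells (Homo sapiens) for antiproliferative activity, read by MTT assay, with a stated time of 72 h (on this read-out lower numbers stand for stronger inhibition and higher numbers for weaker inhibition), compound 1 gives > 20000 nM, which is a limit and not a number. In this assay compound 2 gives > 20000 nM, again a limit. Compound 1 therefore stands at the limit of > 20000 nM in this assay, at which 2 of the 2 values shown sit, with no measured number to start from.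

Compound 3 `CCCCCCCC(=O)Oc1ccc(C(=O)C2=C3OC(C)(C)[C@@H](CC=C(C)C)C[C@@]34C[C@@H](CC=C(C)C)C(C)(C)[C@H]3CCC(C)(C)O[C@]34OC2=O)cc1OC(=O)CCCCCCC` changes the core of compound 1 at a second such oxygen: heptylcarbonyl in place of hydrogen on an oxygen on an aromatic ring. Its hydroxy thus becomes (heptylcarbonyl)oxy. Among the measured compounds shown here, the only measured step that bears on this change is a step that the two limits leave unreadable from compound 1 to compound 2, which swaps a heptylcarbonyl for hydrogen. That step has no readable size to carry over, so it points in neither direction. The expectation in this assay is therefore no step beyond the scatter, and the assay will most likely report only a limit again. The estimated step is a step that the limit leaves unreadable from compound 1 to compound 3. For compound 3 the estimated value is 25000 nM, with an expected range from 12000 nM to 60000 nM.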

Compound 3, half-maximal inhibitory concentration: > 20000 nM
Compound 3: no number, only a limit; the forecaster's own chance of this, stated with the estimate: 85%; the middle value does not contradict the limit.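

In this assay, among the compounds shown here, compound 3 gives > 20000 nM, a limit and not a number, so no step from compound 1 to compound 3 can be read. All the compounds shown end in the same place: the limit of > 20000 nM in this assay, at which 3 of the 3 values shown sit. Left open is whether a heptylcarbonyl on an oxygen on an aromatic ring shifts activity at all, as none of the three compounds has a measured number.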